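Swapping the aryl on the exocyclic double bond of compound 2

A few compounds are considered here, and "the series" means these few. Any claim that something is new, unique, unknown or untested is made for them only; others in the source may bear on it.

Measured compounds:
- compound 1, `COc1ccc(/C=C2\C(=O)N(c3c(Cl)cccc3Cl)c3ccccc32)cc1OC`: > 100 ug/mL
- compound 2, `O=C1/C(=C\c2c(Cl)cccc2Cl)c2ccccc2N1c1c(Cl)cccc1Cl`: > 100 ug/mL
- compound 3, `Cc1ccc2nc(Cl)c(/C=C3\C(=O)N(c4c(Cl)cccc4Cl)c4ccccc43)cc2c1C`: > 100 ug/mL

All three share a core with a 2,6-dichlorophenyl on the ring nitrogen and differ in the aryl group hanging from the exocyclic double bond. In a functional assay on B16-F10 cells (Homo sapiens) for cytotoxicity against B16-F10 (Mus musculus), read by MTT assay, with a stated time of 72 h (on this read-out higher numbers stand for an effect only at larger amounts of compound and lower numbers for an effect already at smaller amounts), compound 1 gives > 100 ug/mL, which is a limit of the assay rather than a number. Compound 2 likewise gives > 100 ug/mL, again only a limit. Compound 3 gives > 100 ug/mL, also a limit. So compound 2 stands where every compound stands so far: at the limit, summed up as the limit of > 100 ug/mL in this assay, at which 3 of the 3 values shown sit, and nothing separates the three from one another.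

Compound 4, `O=C1/C(=C\c2ccccc2[N+](=O)[O-])c2ccccc2N1c1c(Cl)cccc1Cl`, has not been measured in this assay. It differs from compound 2 by 2-nitrophenyl in place of 2,6-dichlorophenyl on a double-bonded chain carbon bound to a double-bonded ring carbon. Within the data shown here, with no step between measured compounds to lean on, the change is expected to give at most a modest step, if any beyond the scatter, toward an effect at smaller amounts. Compound 4 is therefore expected to give about 100 ug/mL, in a range from 30 ug/mL to 300 ug/mL. That estimate means a step of a number no higher from compound 2 to compound 4 (the limit leaves the size open), with a real chance that the assay again reports only a limit.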

Compound 4, concentration for half-maximal effect: > 100 ug/mL
Compound 4 was reported as a limit (the forecaster's own chance of this, stated with the estimate: 65%); the middle value lies on the limit itself.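

Among these compounds, compound 2 and compound 4 are both reported only as a limit rather than a number, so no step between them can be read. The compounds shown leave open whether changing the aryl group on the exocyclic double bond alters the result in this assay at all.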